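This account rests on a few compounds, and the source may have more. Where it says the series, first, only, none or still open, it means among the compounds named here.

Two members of the series have been measured in an in vitro assay on HEK385-7 cells for displacement of a labelled ligand from prostaglandin D2 receptor 2 (Homo sapiens); on this read-out lower numbers stand for stronger inhibition and higher numbers for weaker inhibition. Compound 1 `O=C(O)Cc1sc(C(c2ccc(F)cc2)c2ccc(F)cc2)nc1-c1ccc(Cl)cc1` gives 9.7 nM in this assay. Compound 2 `O=C(O)Cc1sc(C(c2ccccc2)c2ccc(F)c(F)c2)nc1-c1ccc(F)cc1` gives 10 nM in this assay. Compound 1 carries the lower of the two numbers, but the gap to compound 2 lies within the scatter, so the two values show no real separation and neither compound can be called the more potent.

Compound 3 `Nc1cc(-c2nc(C(c3ccc(F)cc3)c3ccc(F)cc3)sc2CC(=O)O)cc(F)n1` has not yet been measured in this assay. It departs from compound 1 at a single site: 2-amino-6-fluoropyridin-4-yl in place of 4-chlorophenyl on an aromatic carbon. Among the measured compounds shown here, no measured pair differs only at this site, so the size of this step cannot be read from data; the two measured values together say only that the shared core tolerates variation in the aryl rings without a change beyond the scatter.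

In the absence of a comparable step, a modest move toward a weaker number is expected, not a large one, and a step within the scatter is also possible. The expected step is a 2.1-fold higher number from compound 1 to compound 3 (0.31 log units; beyond the scatter). Compound 3 is estimated to give 20 nM in this assay, with a range from 5 nM to 80 nM.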

Compound 3, half-maximal inhibitory concentration: 220 nM
The estimate for compound 3 lay 11-fold (1.04 log units) below the measured number, outside the stated range (above it).
By their numbers in this assay, from the lowest: compounds 1 and 2 (each within the scatter of the next); then compound 3.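

In this assay, the position on the aromatic carbon of the five-membered ring, next to the ring nitrogen and next to the ring atom that bears the carboxymethyl group, is now shown to respond strongly to the group it carries: 2-amino-6-fluoropyridin-4-yl in place of 4-chlorophenyl gives (a 23-fold higher number from compound 1 to compound 3 (1.36 log units; beyond the scatter)), a large step and the first that can be read at this site. Compounds 1 and 2 lie within the scatter of each other despite differing in more than one place, but that agreement does not extend to every aryl group here, so the tolerance they suggested has a clear limit at this position. Nothing measured on these compounds bears on what lies behind the step.

The change replaces the ring and adds the amine and the fluorine at once, so the compounds shown do not separate the contribution of each. An aminophenyl group, or a fluoropyridinyl group without the amine, at this position would show whether the amine, the ring nitrogen or the fluorine accounts for the step.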